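Silyl for acetyl in a cytotoxic acetate series

The source may report more compounds than this note shows. Statements on the series, on what has been measured and on what is new or still open speak of the compounds shown alone.

Going by the values given here, in a functional assay on ASK cells (Rattus norvegicus) for cytotoxicity, read by sulforhodamine B assay (on this read-out lower numbers stand for an effect already at smaller amounts and higher numbers for an effect only at larger amounts of compound), compound 1 `C=C1CC[C@@H]2[C@](C)(COC(C)=O)[C@H](OC(C)=O)CC[C@@]2(C)[C@@H]1C/C=C1/C(=O)OC[C@H]1OC(C)=O` gives 11.4 uM, the lower of the two numbers so far. Compound 2 `C=C1CC[C@@H]2[C@](C)(CO)[C@H](OC(C)=O)CC[C@@]2(C)[C@@H]1C/C=C1/C(=O)OC[C@H]1O` gives 58.1 uM, a gap beyond the scatter, though the two structures differ in more than one place and no single change can be read from them. Compound 3 `C=C1CC[C@@H]2[C@](C)(CO[Si](C)(C)C(C)(C)C)[C@H](OC(C)=O)CC[C@@]2(C)[C@@H]1C/C=C1/C(=O)OC[C@H]1OC(C)=O` departs from compound 1 at one place, on an oxygen on a saturated carbon: a group of 7 heavy atoms (6 carbon, 1 silicon; no ring) in place of a group of 3 heavy atoms (2 carbon, 1 oxygen; no ring), on an oxygen on a saturated carbon. Among the compounds with values here, no measured step covers such an exchange, so the expectation starts from compound 1 at 11.4 uM and no step beyond the scatter is expected in this assay, with wide uncertainty in either direction. The expected change is a 1.1-fold lower number from compound 1 to compound 3 (0.06 log units; within the scatter). Compound 3 is estimated at 10 uM, with an expected range from 3.5 uM to 30 uM.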

Compound 3, concentration for half-maximal effect: 1.22 uM
Compound 3: middle estimate off by 8.2-fold (0.91 log units), on the high side, and the stated range ends above it.
By their numbers in this assay, from the lowest: compound 3; then compound 1; then compound 2.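

Exchanging acetyl for a silyl group of 7 heavy atoms (6 carbon, 1 silicon; no ring), on an oxygen on a saturated carbon, gives a 9.3-fold lower number from compound 1 to compound 3 (0.97 log units; beyond the scatter) in this assay. Going by these compounds alone, this is the first change that can be read at a single place, and it shows that this oxygen accepts the larger group while the number moves down, beyond the scatter. Nothing measured here bears on the reason for this step.

The compounds shown leave open whether a methyl ether, a benzyl ether or a trimethylsilyl group on this oxygen would move the number in the same direction. From the compounds shown here alone, it also remains open whether the same exchange on the other acetyl-bearing oxygens of the core of compound 1 would do so.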